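Replacing the indolyl group with benzylsulfanyl

This account rests on a few compounds, and the source may have more. Where it says the series, first, only, none or still open, it means among the compounds named here.

Measured in a functional assay on CCRF-CEM cells (Homo sapiens) for inhibition, read by XTT assay, with a stated time of 72 h; on this read-out lower numbers stand for stronger inhibition and higher numbers for weaker inhibition:
Compound 1 `[N-]=[N+]=NCc1ncnc2c1ncn2[C@@H]1O[C@H](CO)[C@@H](O)[C@H]1O`: 340 nM
Compound 2 `OC[C@H]1O[C@@H](n2cnc3c(Cn4ccc5ccccc54)ncnc32)[C@H](O)[C@@H]1O`: 1960 nM

Compound 2 has the higher of the two numbers, so it is the weaker inhibitor of this pair. Among the measured compounds shown here, the only measured step is a 5.8-fold higher number from compound 1 to compound 2 (0.76 log units; beyond the scatter), where 1H-indol-1-yl takes the place of azido. That step shows that a change at this carbon can shift the number, but it says nothing about benzylsulfanyl itself.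

Compound 3 `OC[C@H]1O[C@@H](n2cnc3c(CSCc4ccccc4)ncnc32)[C@H](O)[C@@H]1O` changes the same place again: benzylsulfanyl in place of 1H-indol-1-yl on a saturated chain carbon bound to an aromatic carbon. Here, benzylsulfanyl stands in place of 1H-indol-1-yl on a saturated chain carbon bound to an aromatic carbon. The entering and leaving groups are close in size, and both carry a six-membered aromatic ring of carbon only. No step beyond the scatter is therefore expected in this assay, and no direction can be favoured. The estimated change is a 1.3-fold lower number from compound 2 to compound 3 (0.12 log units; within the scatter). Compound 3 is expected at about 1500 nM, within an estimated range of 400 nM to 5000 nM.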

Compound 3, half-maximal inhibitory concentration: 4650 nM
Compound 3: the middle estimate sits 3.1-fold (0.49 log units) below what was measured; the range from low to high includes it.
By their numbers in this assay, from the lowest: compound 1; then compound 2; then compound 3.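

In this assay, benzylsulfanyl in place of the indolyl group gives a 2.4-fold higher number from compound 2 to compound 3 (0.38 log units; beyond the scatter) and shows that two groups, each carrying a six-membered aromatic ring of carbon only, need not behave alike at this carbon. Measured against azido, the same group gives a 14-fold higher number from compound 1 to compound 3 (1.14 log units; beyond the scatter) as the largest step shown here, and both ring-bearing groups leave compound 1 with the lowest number of the three. No measurement available here explains why these groups differ.

As far as these compounds go, whether a simple amine or a carboxylic acid on this carbon would bring the number closer to that of compound 1 remains open. Also open, from the compounds shown here alone, is how benzyloxy, with oxygen in place of sulfur, or a shorter methylsulfanyl group would compare with benzylsulfanyl.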